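Swapping One Fluoro for Chloro in Compound 3

A few compounds are considered here, and "the series" means these few. Any claim that something is new, unique, unknown or untested is made for them only; others in the source may bear on it.

Measured in a functional assay on MCF7 cells (Homo sapiens); a higher number here means a weaker inhibitor of growth, a lower number a stronger inhibitor of growth:
- compound 1 `O=S(=O)(/C=C/c1ccccc1)Cc1ccc(Nc2ncnc3ccccc23)cc1`: 74000 nM
- compound 2 `O=S(=O)(/C=C/c1ccc(Cl)cc1Cl)Cc1ccc(Nc2ncnc3ccccc23)cc1`: 4000 nM
- compound 3 `O=S(=O)(/C=C/c1ccc(F)cc1F)Cc1ccc(Nc2ncnc3ccccc23)cc1`: > 100000 nM (a limit)

Compound 3 reads > 100000 nM, which is a limit of the assay and not a number. Its true position in this assay is therefore unknown on the weak side of the series.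

Compound 4 `O=S(=O)(/C=C/c1ccc(F)cc1Cl)Cc1ccc(Nc2ncnc3ccccc23)cc1` differs from compound 3 by chloro in place of fluoro on an aromatic carbon, ortho to a large group and meta to a fluoro group. The 2,4-difluorophenyl thus becomes 2-chloro-4-fluorophenyl, which shares its chloro group with compound 2 and its fluoro group with compound 3.

Among the compounds with values here, two measured steps bear most directly on this change. The step of an at least 25-fold higher number from compound 2 to compound 3 (1.39 log units; beyond the scatter) is large, and so is a 19-fold lower number from compound 1 to compound 2 (1.27 log units; beyond the scatter). By contrast, an at least 1.3-fold higher number from compound 1 to compound 3 (0.13 log units; that floor lies within the scatter) shows that the fluoro pair gains nothing measurable over the bare phenyl.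

Since compound 4 makes only part of the change that separates compound 3 from compound 2, part of that large gap is expected to be recovered. The expected step is an at least 6.6-fold lower number from compound 3 to compound 4 (0.82 log units; beyond the scatter), towards a lower number. For compound 4 the estimate is 15000 nM, with an expected range from 3000 nM to 80000 nM.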

Compound 4, concentration for 50% growth inhibition: 21000 nM
Compound 4: the middle estimate sits 1.4-fold (0.15 log units) below what was measured, and the stated range covers the measured number.
By their numbers in this assay, from the lowest: compound 2; then compound 4; then compound 1. At a limit, above all of these: compound 3.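

In this assay, chloro in place of fluoro on this aromatic carbon, ortho to a large group, is enough by itself to bring the compound back from the weak edge of the series, and the change gives an at least 4.7-fold lower number from compound 3 to compound 4 (0.67 log units; beyond the scatter). That step is only a floor, because compound 3 stands at a limit of the assay and not at a number: the limit of > 100000 nM in this assay, at which 1 of the 4 values shown sits.

The single chloro does not account for the whole of the gain, since the remaining change, at the other halogen carbon, gives a 5.3-fold higher number from compound 2 to compound 4 (0.72 log units; beyond the scatter), while the 2-chloro-4-fluorophenyl still improves on the bare phenyl with a 3.5-fold lower number from compound 1 to compound 4 (0.55 log units; beyond the scatter); both halogen carbons therefore count in this series, and the chloro on each one moves the number towards stronger inhibition of growth.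

The compounds shown leave open how large the step from fluoro to chloro really is on this carbon. They also leave open whether a bromo or a methyl group there would go further than chloro, or whether a methoxy group would serve at all.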